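A cyclopropyl replaces 2-methoxyphenyl at the assay limit

This account rests on a few compounds, and the source may have more. Where it says the series, first, only, none or still open, it means among the compounds named here.

In a functional assay on A549 cells (Homo sapiens) for antiproliferative activity, read by MTT assay, with a stated time of 72 h (on this read-out lower numbers stand for stronger inhibition and higher numbers for weaker inhibition), compound 1 `O=C1O[C@H]([C@@H](O)Cn2cc(-c3ccc(Br)cc3)nn2)C(OCc2ccccc2)=C1OCc1ccccc1` gives 750 nM. Compound 2 `Cc1ccc(-c2cn(C/C=C3\OC(=O)C(OCc4ccccc4)=C3OCc3ccccc3)nn2)cc1` reads > 100000 nM, which is a limit of the assay and not a number. Compound 3 `COc1ccccc1-c1cn(C[C@H](O)[C@H]2OC(=O)C(OCc3ccccc3)=C2OCc2ccccc2)nn1` reads > 100000 nM, again only a limit. Compound 3 therefore stands on (the limit of > 100000 nM in this assay, at which 2 of the 3 values shown sit).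

Compound 4 `O=C1O[C@H]([C@@H](O)Cn2cc(C3CC3)nn2)C(OCc2ccccc2)=C1OCc1ccccc1` keeps the core of compound 3 but carries cyclopropyl in place of 2-methoxyphenyl on an aromatic carbon. Among the compounds with values here, one measured step bears on this change, at the same carbon: an at least 130-fold higher number from compound 1 to compound 3 (2.12 log units; beyond the scatter), a large step beyond the scatter. It shows that the group on this carbon can move the number strongly, but it is a single step and neither of its groups is cyclopropyl. A clear move toward a lower number is therefore expected in this assay, though probably not all the way back to compound 1. The expected change is an at least 3.3-fold lower number from compound 3 to compound 4 (0.52 log units; beyond the scatter), and a reading at the limit remains possible. For compound 4 the estimated value is 30000 nM, with an expected range from 3000 nM to 100000 nM.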

Compound 4, half-maximal inhibitory concentration: 43900 nM
The estimate for compound 4 lay 1.5-fold (0.17 log units) below the measured number; the measured number falls inside the stated range.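

In this assay, compound 4 shows that a group with a three-membered non-aromatic ring of carbon only, at this aromatic carbon, can give a measurable number: an at least 2.2-fold lower number from compound 3 to compound 4 (0.35 log units; beyond the scatter). Against the bromine-bearing group, a 59-fold higher number from compound 1 to compound 4 (1.77 log units; beyond the scatter), so cyclopropyl falls between the two phenyl groups, and an aromatic ring at this carbon does not by itself set the number. The first of these steps is only a bound, since compound 3 reads at a limit of the assay and not at a number: the limit of > 100000 nM in this assay, at which 2 of the 4 values shown sit.

On these data alone, whether plain phenyl, 4-chlorophenyl or 2-bromophenyl at this carbon would stay close to compound 1 remains open. Also open, as far as these compounds go, is whether an amine, a carboxylic acid or a longer alkyl chain here would read nearer to compound 1 or to compound 4.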